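A few compounds are considered here, and "the series" means these few. Any claim that something is new, unique, unknown or untested is made for them only; others in the source may bear on it.

In a functional assay on NB1 cells (Homo sapiens) for cytotoxicity, read by MTT assay, with a stated time of 3 days (a lower number here means a stronger inhibitor, a higher number a weaker inhibitor), compound 1 (`N#Cc1c(NN)nc(SCc2nc3ccccc3[nH]2)nc1-c1ccccc1`) gives 5.4 nM and compound 2 (`CNc1nc(SCc2nc3ccccc3[nH]2)nc(-c2ccccc2)c1C#N`) gives 4.46 nM while compound 3 (`N#Cc1c(Nc2nccs2)nc(SCc2nc3ccccc3[nH]2)nc1-c1ccccc1`) gives 3.2 nM on the shared core. Compound 2 is not separated from either of the others, with a 1.2-fold lower number from compound 1 to compound 2 (0.08 log units; within the scatter) on one side and a 1.4-fold lower number from compound 2 to compound 3 (0.14 log units; within the scatter) on the other.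

Compound 4 (`N#Cc1c(NNC(N)=S)nc(SCc2nc3ccccc3[nH]2)nc1-c1ccccc1`) differs from compound 2 in one place, on a nitrogen on an aromatic ring (a group of 4 heavy atoms (1 carbon, 2 nitrogen, 1 sulfur; no ring) in place of one carbon atom, on a nitrogen on an aromatic ring). For the measured compounds named here, all the measured steps are exchanges at that same place, and the remaining one is a 1.7-fold lower number from compound 1 to compound 3 (0.23 log units; within the scatter) as well. Each of these three steps is small, and none leaves the scatter, even with the ring that compound 3 carries there. Going by the values given here, no measured compound carries the entering group of compound 4, so these steps are only indirect evidence and the range has to stay wide.

On this basis, no step beyond the scatter is expected in this assay and no clear direction can be called. The estimated change is a 1.1-fold lower number from compound 2 to compound 4 (0.03 log units; within the scatter) on this reading. Compound 4 is expected at about 4.2 nM with an estimated range from 1.5 nM to 13 nM in this measurement.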

Compound 4, half-maximal inhibitory concentration: 5.81 nM
Compound 4: the middle estimate sits 1.4-fold (0.14 log units) below what was measured, within the range that was stated.
By their numbers in this assay, from the lowest: compounds 3, 2, 1 and 4 (each within the scatter of the next).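

In this assay, the place on a nitrogen on an aromatic ring also accepts an open group with a double bond outside aromatic rings, and the change stays small, with a 1.3-fold higher number from compound 2 to compound 4 (0.11 log units; within the scatter) and a 1.8-fold higher number from compound 3 to compound 4 (0.26 log units; within the scatter). The same holds when the group is read as an addition to the amine nitrogen of compound 1, with a 1.1-fold higher number from compound 1 to compound 4 (0.03 log units; within the scatter), so growing out from that nitrogen has shown no step beyond the scatter either. Nothing among the available data accounts for this tolerance, and no independent measurement bears on the result.

What remains open is whether any group at this place can move the number beyond the scatter at all, since a carboxylic acid, a longer chain such as butyl and a larger ring such as phenyl are not among the compounds shown. These four compounds also differ only at this one place, so they leave open whether the same insensitivity would hold on a changed core, or in cells other than those of this assay.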